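Cytotoxicity outlook for compound 4 built on compound 3

The source may report more compounds than this note shows. Statements on the series, on what has been measured and on what is new or still open speak of the compounds shown alone.

The measured compounds:
compound 1 `CC[C@H]1CC[C@H](c2ccc(NC(=S)Nc3cccc(C(F)(F)F)c3)cc2)CC1`, which in an ADME assay on BHK cells (Mesocricetus auratus) for cytotoxicity, read by MTT assay, with a stated time of 96 h (on this read-out lower numbers stand for higher toxicity in this test and higher numbers for lower toxicity in this test), gives 10000 nM
compound 2 `COc1cccc(NC(=S)Nc2cccc(C(F)(F)F)c2)c1`, which in this assay gives 12000 nM
compound 3 `FC(F)(F)c1cccc(NC(=S)Nc2ccccc2)c1`, which in this assay gives 41000 nM

Compound 3 holds the highest number of the three, which in this assay means the lowest toxicity. Its nearest neighbour is compound 2, whose number is lower beyond the scatter, and compound 1 sits lower still. Both measured steps end at compound 3: a 4.1-fold higher number from compound 1 to compound 3 (0.61 log units; beyond the scatter) and a 3.4-fold higher number from compound 2 to compound 3 (0.53 log units; beyond the scatter). Each removes a group from an aromatic carbon of the shared core, and each raised the number modestly.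

Compound 4 `FC(F)(F)c1cccc(NC(=S)NCc2ccco2)c1` changes a different part of compound 3: (furan-2-yl)methyl in place of phenyl on an amide-type nitrogen. Within the data shown here, neither measured step touches this nitrogen, so no step bears directly on the change; the two steps show only that single changes on this core have so far moved this assay by modest amounts in one direction. For compound 4 a step of at most modest size is therefore expected, and its direction cannot be read from the data, so a 1.2-fold lower number from compound 3 to compound 4 (0.07 log units; within the scatter) is taken as close to no change. Compound 4 is estimated at 35000 nM in this assay, within a range of 10000 nM to 120000 nM.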

Compound 4, half-maximal cytotoxic concentration: 48000 nM
Compound 4: the middle estimate sits 1.4-fold (0.14 log units) below what was measured; the range from low to high includes it.
By their numbers in this assay, from the lowest: compounds 1 and 2 (each within the scatter of the next); then compounds 3 and 4 (each within the scatter of the next).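

Swapping phenyl for (furan-2-yl)methyl on the amide-type nitrogen gives a 1.2-fold higher number from compound 3 to compound 4 (0.07 log units; within the scatter) in this assay, so compound 3 and compound 4 cannot be told apart on this read-out. Among these compounds, this is the first look at that nitrogen, and it differs from the two earlier steps on aromatic carbons, which both lay beyond the scatter: here a six-membered aromatic ring of carbon only gives way to a five-membered aromatic ring with 1 hetero atom and a hydrogen-bond acceptor enters, yet the cytotoxicity number shows no measurable shift. Nothing measured here offers a reason for this result.

One swap at this nitrogen cannot separate the part played by the furan ring from that of the methylene link that carries it, and a benzyl group or a furan-2-yl group placed directly on the nitrogen would pull those two apart. From the compounds shown here alone, it also remains open whether this nitrogen would accept very different groups in the same way, such as a plain butyl chain, a longer chain ending in an amine, or one ending in a carboxylic acid.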